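This account rests on a few compounds, and the source may have more. Where it says the series, first, only, none or still open, it means among the compounds named here.

Measured so far in an assay on CHO cells for displacement of a labelled ligand from prostaglandin D2 receptor 2 (Homo sapiens), read by scintillation counting; a lower number here means a stronger inhibitor, a higher number a weaker inhibitor:
compound 1 `CCCS(=O)(=O)c1cccc(C#Cc2cc(Cl)ccc2OCC(=O)O)c1`, 9 nM
compound 3 `CCCS(=O)(=O)c1ccc(F)c(C#Cc2cc(Cl)ccc2OCC(=O)O)c1`, 3.4 nM
compound 2 `O=C(O)COc1ccccc1C#Cc1ccccc1Cl`, 747 nM

Compound 1 stands second highest of the three numbers. The nearest neighbour is reached by a 2.6-fold lower number from compound 1 to compound 3 (0.42 log units; beyond the scatter), a fluoro in place of hydrogen on an aromatic carbon. Compound 2 gives the furthest number and is the far weaker inhibitor of the set.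

Compound 4 `CS(=O)(=O)c1cccc(C#Cc2cc(Cl)ccc2OCC(=O)O)c1` differs from compound 1 by hydrogen in place of ethyl on a saturated chain carbon bound to a sulfonyl sulfur. Among the compounds with values here, no measured step bears on this chain: the one step known concerns an aromatic fluoro, and the gap from compound 1 to compound 2 comes from losing the whole propylsulfonyl group, not from shortening it. Without a direct guide, the step of a 1.7-fold higher number from compound 1 to compound 4 (0.22 log units; within the scatter) is expected to stay small. Compound 4 is therefore estimated at 15 nM in this assay, range 5 nM to 45 nM.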

Compound 4, inhibition constant: 15 nM
Compound 4: the middle estimate sits on the measured number at the digits printed; the range from low to high includes it.
By their numbers in this assay, from the lowest: compound 3; then compounds 1 and 4 (each within the scatter of the next); then compound 2.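

In this assay, cutting propylsulfonyl back to methylsulfonyl gives a 1.7-fold higher number from compound 1 to compound 4 (0.22 log units; within the scatter), so at this place the ethyl can give way to hydrogen without a step beyond the scatter. Within the data shown here, this is the first direct reading on the chain bound to the sulfonyl sulfur, which the aromatic fluoro step could not give. Nothing at hand accounts for this result.

From the compounds shown here alone, whether a longer chain such as butyl, or an amine on the sulfonyl sulfur, would hold the number stays open. So does whether the fluoro in place of hydrogen seen in compound 3 would carry over to compound 4.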